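The source may report more compounds than this note shows. Statements on the series, on what has been measured and on what is new or still open speak of the compounds shown alone.

Of the compounds shown here, three with a shared core have been tested in a functional assay on HCT-116 cells (Homo sapiens) for inhibition, read by CCK-8 assay, with a stated time of 48 h; a higher number here means a weaker inhibitor, a lower number a stronger inhibitor. Compound 1 `COc1cc(-c2ccnc3cc(-c4ccc(C)cc4)nn23)cc(OC)c1OC` gives 48 nM, compound 2 `COc1cc(-c2ccnc3cc(-c4c[nH]c5ccccc45)nn23)cc(OC)c1OC` gives 35 nM, and compound 3 `COc1cc(-c2ccnc3cc(-c4ccc5ccn(C)c5c4)nn23)cc(OC)c1OC` gives 1040 nM. Compound 2 has the lowest number of the three, but it sits close to compound 1: the change a 1.4-fold lower number from compound 1 to compound 2 (0.14 log units; within the scatter) is within the scatter. The gap to compound 3 is a different matter, as a 30-fold higher number from compound 2 to compound 3 (1.47 log units; beyond the scatter) and a 22-fold higher number from compound 1 to compound 3 (1.34 log units; beyond the scatter) both show.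

Compound 4 `COc1cc(-c2ccnc3cc(-c4cn(CO)c5ccccc45)nn23)cc(OC)c1OC` is not yet measured. It differs from compound 2 by hydroxymethyl in place of hydrogen on an aromatic nitrogen. For the measured compounds named here, none of the measured steps tries a change of this kind: each of them swaps the whole aryl group on the core, and the one step that involves a methylated aromatic nitrogen, from compound 2 to compound 3, also moves the point of attachment, so it cannot be read as a test of the nitrogen substituent alone. The expectation is therefore cautious: compound 4 is estimated to land near compound 2, with a step of a 1.3-fold higher number from compound 2 to compound 4 (0.11 log units; within the scatter) that is within the scatter, and an estimated value of 45 nM between 15 nM and 140 nM.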

Compound 4, half-maximal inhibitory concentration: 128 nM
Estimate against measurement, compound 4: 2.8-fold (0.45 log units) below; the range from low to high includes it.
By their numbers in this assay, from the lowest: compounds 2 and 1 (each within the scatter of the next); then compound 4; then compound 3.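

In this assay, hydroxymethyl in place of hydrogen on the aromatic nitrogen gives a 3.7-fold higher number from compound 2 to compound 4 (0.56 log units; beyond the scatter), so this single change makes the inhibitor weaker by a modest step that lies beyond the scatter. For the compounds shown here, this is the first reading of a substituent on this nitrogen with the point of attachment held fixed, something the step to compound 3 could not give, as it also moved that point. No accompanying measurement bears on this result, so the reason for the loss remains unexplained.

With only one group shown on this nitrogen, it remains open whether any substituent there costs activity or whether the loss is specific to hydroxymethyl. A plain methyl on the same nitrogen of compound 2, or a longer chain ending in an amine or a carboxylic acid, would help separate these two possibilities.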